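Compound 1 to compound 4: butyl in place of phenyl

A few compounds are considered here, and "the series" means these few. Any claim that something is new, unique, unknown or untested is made for them only; others in the source may bear on it.

Three compounds frame the series in an ADME assay on the whole organism (strain Sprague-Dawley) for pharmacokinetics, with Rattus norvegicus as the target; a higher number here means faster removal of the compound, a lower number slower removal. Compound 1 (`O=C(NCc1cc(Cl)ccc1-n1cnnn1)[C@@H]1CC=NN1C(=O)[C@H](O)c1ccccc1`) gives 21 mL/min/kg, compound 2 (`CC(C)(C)[C@@H](O)C(=O)N1C[C@@H]2C[C@@H]2[C@H]1C(=O)NCc1cc(Cl)ccc1-n1cnnn1`) gives 26 mL/min/kg, and compound 3 (`O=C(NCc1cc(Cl)ccc1-n1cnnn1)[C@@H]1C[C@H]2C[C@H]2N1C(=O)[C@H](O)c1ccccc1`) gives 18 mL/min/kg. All three values lie within the usual scatter of one another, so compound 1 stands in a tight group and no order can be read from these numbers.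

Compound 4 (`CCCC[C@@H](O)C(=O)N1N=CC[C@H]1C(=O)NCc1cc(Cl)ccc1-n1cnnn1`) keeps the core of compound 1 and alters one group: butyl in place of phenyl on a saturated chain carbon bound to a carbonyl carbon and an oxygen on a saturated carbon. The change is butyl in place of phenyl on a saturated chain carbon bound to a carbonyl carbon and an oxygen on a saturated carbon.

Going by the values given here, no two measured compounds differ in one place only, so no measured step speaks directly to this change. The nearest guide is compound 2, which also has no phenyl but has a different core, and compound 2 gives 26 mL/min/kg. On that thin evidence, a small upward move in this assay is expected, not one beyond the scatter. The expected step is a 1.3-fold higher number from compound 1 to compound 4 (0.12 log units; within the scatter). For compound 4 the estimated clearance is 28 mL/min/kg, with an expected range of 14 mL/min/kg to 55 mL/min/kg.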

Compound 4, clearance: 38 mL/min/kg
Compound 4: middle estimate off by 1.4-fold (0.13 log units), on the low side; the measured number falls inside the stated range.
By their numbers in this assay, from the lowest: compounds 3, 1, 2 and 4 (each within the scatter of the next, the first and the last beyond it).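

Going by these compounds alone, at the saturated chain carbon bound to a carbonyl carbon and an oxygen on a saturated carbon, butyl in place of phenyl gives the first step in this assay that can be read on a single change: a 1.8-fold higher number from compound 1 to compound 4 (0.26 log units; within the scatter). Within the data shown here, the earlier compounds offered no pair differing in one place, so this is the only direct reading of this position, and it shows that exchanging the six-membered aromatic ring for an open chain on the core of compound 1 leaves the clearance within the scatter. Nothing at hand bears on the reason for this step.

This single step cannot show whether the same exchange on the core of compound 3 would give a step of like size. Also open, going by these compounds, is how other groups at this carbon would read against phenyl and butyl, such as ethyl, a saturated ring such as cyclohexyl, a pyridine ring, or a chain ending in an amine or a carboxylic acid.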